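Removing the acetyl: from compound 3 to compound 4

The source may hold more compounds than are shown below. What is called first, only, known or untested is meant among the compounds shown, and "the series" means these compounds.

Measured compounds:
compound 1 `COc1cc(CC[C@@H](O)C[C@@H](O)CCc2ccc(O)cc2)cc(O)c1O` gives 2410 nM
compound 2 `O=C(CCc1ccc(O)cc1)C[C@@H](O)CCc1ccccc1` gives 75700 nM
compound 3 `CC(=O)O[C@H](CCc1ccc(O)cc1)C[C@H](O)CCc1ccc(O)cc1` gives 32000 nM

All three were tested in a functional assay on RAW264.7 cells (Mus musculus) for inhibition, read by spectrophotometry and Griess assay, with a stated time of 24 h; on this read-out lower numbers stand for stronger inhibition and higher numbers for weaker inhibition. On those numbers compound 3 stands second highest of the three. Its nearest neighbour is compound 2, whose number is higher by a margin beyond the usual scatter; compound 1 is the furthest away, with a much lower number, again beyond the scatter.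

Compound 4 `Oc1ccc(CC[C@@H](O)C[C@H](O)CCc2ccc(O)cc2)cc1` has not yet been measured in this assay. It differs from compound 3 in one place: hydrogen in place of acetyl on an oxygen on a saturated carbon. For the measured compounds named here, no pair of measured compounds covers this change, so the size of the step is not known from the data. Still, a step down is expected, beyond the scatter, because compound 1, which likewise carries a free hydroxy at that place, gives 2410 nM. The expected step is a 3.2-fold lower number from compound 3 to compound 4 (0.51 log units; beyond the scatter). Compound 4 is therefore estimated at 10000 nM, with a range from 3000 nM to 30000 nM.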

Compound 4, half-maximal inhibitory concentration: > 100000 nM
Compound 4: no number, only a limit; the forecaster's own chance of this, stated with the estimate: 5%; middle value at least 10-fold (1.00 log units) from the limit.
By their numbers in this assay, from the lowest: compound 1; then compound 3; then compound 2. At a limit, above all of these: compound 4.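

In this assay, the acetoxy to hydroxy change on this oxygen on a saturated carbon goes the way of weaker inhibition: an at least 3.1-fold higher number from compound 3 to compound 4 (0.49 log units; beyond the scatter). Compound 4 gives > 100000 nM, a limit of the assay and not a number, so the step can be read only as a bound: the limit of > 100000 nM in this assay, at which 1 of the 4 values shown sits. Compound 1 also carries a free hydroxy at this place but differs from compound 4 in more than one place, so a free hydroxy there cannot be tied to its value, and on this one pair the acetyl goes with the stronger inhibition.

As far as these compounds go, how far the step really reaches remains open. So does whether the acetyl itself matters here, or whether a methyl ether, an amine or a longer acyl chain at the same oxygen would serve as well.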